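Hydroxymethyl in Place of Pyrazinyl on an Adenosine Deaminase Inhibitor

The source may hold more compounds than are shown below. What is called first, only, known or untested is meant among the compounds shown, and "the series" means these compounds.

Compound 1 `C[C@H](O)[C@@H](CCc1cccc(Br)c1)n1cnc2c(N)ncnc21` gives 0.6 nM in an assay on isolated protein for inhibition of adenosine deaminase (Bos taurus), with a stated time of 5 min; a higher number here means a weaker inhibitor, a lower number a stronger inhibitor.
Compound 2 `C[C@H](O)[C@@H](CCC1CCCCC1)n1cnc2c(N)ncnc21` gives 1.9 nM in this assay.
Compound 3 `C[C@H](O)[C@@H](CCc1cccc(-c2cnccn2)c1)n1cnc2c(N)ncnc21` gives 1.9 nM in this assay.

Compound 3 stands level with compound 2 at the digits shown, and the two together carry the highest numbers of the three; compound 1 sits apart from them, as the step of a 3.2-fold higher number from compound 1 to compound 3 (0.50 log units; beyond the scatter) shows. Compound 4 `C[C@H](O)[C@@H](CCc1cccc(CO)c1)n1cnc2c(N)ncnc21` differs from compound 3 in one place: hydroxymethyl in place of pyrazin-2-yl on an aromatic carbon. Neither measured step covers this exact change. The step of a 3.2-fold higher number from compound 1 to compound 3 (0.50 log units; beyond the scatter) involves the group that leaves, the pyrazin-2-yl, but compares it with bromo rather than with hydroxymethyl, and the step of a 3.2-fold higher number from compound 1 to compound 2 (0.50 log units; beyond the scatter) concerns a different part of the molecule. Both steps were modest, and all three numbers fall within a narrow band. No step beyond the scatter is therefore expected in this assay for compound 4, in either direction. Compound 4 is expected to give about 2 nM in this assay, within a range from 0.7 nM to 6 nM. This corresponds to an expected step of a 1.1-fold higher number from compound 3 to compound 4 (0.02 log units; within the scatter).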

Compound 4, inhibition constant: 4.6 nM
Estimate against measurement, compound 4: 2.3-fold (0.36 log units) below; the range from low to high includes it.
By their numbers in this assay, from the lowest: compound 1; then compounds 2 and 3 (each within the scatter of the next); then compound 4.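

In this assay, replacing the pyrazin-2-yl ring with hydroxymethyl gives a step beyond the scatter (a 2.4-fold higher number from compound 3 to compound 4 (0.38 log units; beyond the scatter)), so this aromatic carbon is not indifferent to the group it carries. Hydroxymethyl also separates from bromo on the same carbon (a 7.7-fold higher number from compound 1 to compound 4 (0.88 log units; beyond the scatter)), the largest step yet seen at this position, though still modest. The ring no longer holds its edge over cyclohexyl: bromo gave a 3.2-fold higher number from compound 1 to compound 2 (0.50 log units; beyond the scatter), whereas with hydroxymethyl the order reverses (a 2.4-fold higher number from compound 2 to compound 4 (0.38 log units; beyond the scatter)).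

Nothing available here explains why hydroxymethyl gives a higher number than bromo or pyrazin-2-yl. Going by these compounds, it remains open whether an amine, a methoxy group or a carboxylic acid on this aromatic carbon would sit nearer to hydroxymethyl or to bromo.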